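The source may hold more compounds than are shown below. What is called first, only, known or untested is meant among the compounds shown, and "the series" means these compounds.

In a functional assay on microsomes from intestine for inhibition of acyl-CoA:cholesterol acyltransferase (Oryctolagus cuniculus) (a higher number here means a weaker inhibitor, a lower number a stronger inhibitor), compound 2 `CC(C)c1cccc(C(C)C)c1NC(=O)CC(=O)CCCCCCCCCCOC1CCCCO1` gives 57 nM, the lowest of the two numbers recorded so far. Among the compounds with values here, its only neighbour, compound 1 `CCCCCCCCCCCC(=O)C(C)(C)C(=O)N(C)c1c(C(C)C)cccc1C(C)C`, gives 1000 nM in this assay, and that gap lies beyond the usual scatter; since the two structures differ in several places at once, the values alone say nothing about any single change. Compound 3 `CC(C)c1cccc(C(C)C)c1NC(=O)CC(=O)CCCCCCCCCCO` has not yet been measured. It differs from compound 2 in one place only: hydrogen in place of oxan-2-yl on an oxygen on a saturated carbon, so that the long chain now ends in a free hydroxyl rather than a capped oxygen. Within the data shown here, no pair of measured compounds shows this change, so there is nothing to copy a step size from. The expectation is a modest weakening, perhaps only just beyond the scatter, described by the step of a 2.6-fold higher number from compound 2 to compound 3 (0.42 log units; beyond the scatter). Compound 3 is therefore estimated at 150 nM in this assay, within a range of 40 nM to 600 nM.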

Compound 3, half-maximal inhibitory concentration: 230 nM
Compound 3: middle estimate off by 1.5-fold (0.19 log units), on the low side; the range from low to high includes it.
By their numbers in this assay, from the lowest: compound 2; then compound 3; then compound 1.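

Within the data shown here, this is the first pair in the set that differs in one place only, so it gives the first clean reading of a single change. In this assay, putting hydrogen in place of oxan-2-yl on the oxygen at the chain end gives a 4.0-fold higher number from compound 2 to compound 3 (0.61 log units; beyond the scatter), which shows that this end of the chain is not indifferent to what sits on it. The step is modest, and compound 3, with its free hydroxyl, still gives 230 nM.

No measurement here explains the size of this step. Going by these compounds, it remains open whether the oxan-2-yl ring itself matters or any cap on that oxygen would do the same, as a methyl ether or an acetate ester might show, and how an amine, a carboxylic acid or a longer chain would compare.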